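Phenyl in place of pentyl on the ring amine carbon

The source may report more compounds than this note shows. Statements on the series, on what has been measured and on what is new or still open speak of the compounds shown alone.

Going by the values given here, compound 2 `CCCCCCN1CCC(N2CC(c3ccnc4ccc(OC)cc34)OC2=O)CC1` holds the lower of the two numbers measured so far: in an in vitro functional assay on RBL cells for antagonist activity at C-C chemokine receptor type 8 (Homo sapiens), read by FLIPR and calcium flux (on this read-out lower numbers stand for stronger inhibition and higher numbers for weaker inhibition), compound 2 gives 501 nM, while compound 1 `COc1ccc2nccc(C3CN(C4CCN(Cc5cc6ccccc6o5)CC4)C(=O)O3)c2c1` gives 1260 nM. Among the compounds with values here, the only known step, a 2.5-fold lower number from compound 1 to compound 2 (0.40 log units; beyond the scatter), swapped a fused aromatic group for a plain chain. Compound 3 `COc1ccc2nccc(C3CN(C4CCN(Cc5ccccc5)CC4)C(=O)O3)c2c1` puts an aromatic ring back in the same place: phenyl in place of pentyl on a saturated chain carbon bound to an amine nitrogen in a ring. Because that earlier step a 2.5-fold lower number from compound 1 to compound 2 (0.40 log units; beyond the scatter) favoured the chain over the aromatic group, a modest rise in the number is expected here, a 1.6-fold higher number from compound 2 to compound 3 (0.20 log units; within the scatter). In this assay compound 3 is expected to give 800 nM, between 350 nM and 1800 nM.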

Compound 3, half-maximal inhibitory concentration: 12600 nM
The estimate for compound 3 lay 16-fold (1.20 log units) below the measured number; measured number above the stated range.
By their numbers in this assay, from the lowest: compound 2; then compound 1; then compound 3.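

At this position, on a saturated chain carbon bound to an amine nitrogen in a ring, phenyl is a poor replacement for pentyl: this assay shows a 25-fold higher number from compound 2 to compound 3 (1.40 log units; beyond the scatter), a large loss of inhibition. The two aromatic groups are far from interchangeable either, with a 10-fold higher number from compound 1 to compound 3 (1.00 log units; beyond the scatter) on going from 1-benzofuran-2-yl to phenyl, so aromatic groups do not behave as one class here. No measurement at hand explains these gaps. Still open, going by these compounds, is whether a longer chain than pentyl would lower the number further. A naphthyl group could also show whether a fused aromatic group generally keeps more inhibition than phenyl.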